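A few compounds are considered here, and "the series" means these few. Any claim that something is new, unique, unknown or untested is made for them only; others in the source may bear on it.

Of the compounds shown here, three have so far been tested in a functional assay on A549 cells (Homo sapiens) for antiproliferative activity, read by MTT assay, with a stated time of 48 h; a higher number here means a weaker inhibitor, a lower number a stronger inhibitor. Compound 2 `N#Cc1ncn(-c2ccc(F)cc2)c1/N=C/c1ccc(O)cc1` gives 16300 nM, and compound 1 `COc1cc(/C=N/c2c(C#N)ncn2-c2ccc(F)cc2)ccc1O` gives 13600 nM. The change between them, (methoxy in place of hydrogen on an aromatic carbon), produced a 1.2-fold lower number from compound 2 to compound 1 (0.08 log units; within the scatter). Compound 3 `COc1ccc(C2N=C(C(N)=O)c3ncn(-c4ccc(F)cc4)c3N2)cc1` is built on a different core, and the difference between the two cores is not broken down here. In this assay compound 3 gives 10900 nM, which lies within the scatter of both compound 1 and compound 2.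

Compound 4 `COc1ccc(C2N=C(C(N)=O)c3ncn(-c4ccc(F)cc4)c3N2)cc1OC` has not yet been measured. It differs from compound 3 by methoxy in place of hydrogen on an aromatic carbon. Going by the values given here, this is the same kind of change as the one from compound 2 to compound 1, though the surroundings are not identical: here the entering group sits ortho to a methoxy group, whereas in compound 1 it sits ortho to a hydroxy group. Because the earlier change gave only a 1.2-fold lower number from compound 2 to compound 1 (0.08 log units; within the scatter), the step of a 1.1-fold lower number from compound 3 to compound 4 (0.06 log units; within the scatter) is expected to be small as well. Compound 4 is therefore estimated at 9500 nM, with a likely range from 4000 nM to 25000 nM.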

Compound 4, half-maximal inhibitory concentration: 2290 nM
Estimate against measurement, compound 4: 4.1-fold (0.62 log units) above; the measured number lies below the stated range.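

In this assay the step of a 4.8-fold lower number from compound 3 to compound 4 (0.68 log units; beyond the scatter) came from methoxy in place of hydrogen on an aromatic carbon, and it cannot be predicted from the same change on the core of compound 1. Set side by side, the two instances show that the size of this change did not carry over from one core to the other: the same change on two cores in this assay, a 1.2-fold lower number (0.08 log units; within the scatter) from compound 2 to compound 1 and a 4.8-fold lower number (0.68 log units; beyond the scatter) from compound 3 to compound 4, 4.0-fold (0.60 log units) apart, beyond the scatter of two such steps. Going by these compounds alone, this does not show how the change behaves on cores in general or what underlies the gap, since each core supplies only a single pair and the surroundings also differ, with the entering group in compound 4 ortho to a methoxy group and the one in compound 1 sitting on a ring that carries a hydroxy group instead.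

The compounds shown leave open whether an ethoxy group or an amine at the same place on the core of compound 3 would give a similar step. They also leave open whether a carboxylic acid in place of the amide would leave the step intact.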